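Swapping 4-methylphenyl for 1H-indol-3-yl in compound 1

This account rests on a few compounds, and the source may have more. Where it says the series, first, only, none or still open, it means among the compounds named here.

Measured in a functional assay on MCF7 cells (Homo sapiens) for antiproliferative activity; a lower number here means a stronger inhibitor, a higher number a weaker inhibitor:
- compound 1 `CO[C@@H]1[C@@H](O)[C@@H](O)[C@H](Oc2ccc3c(c2C)OC(=O)C(n2cc(-c4ccc(C)cc4)nn2)C3)OC1(C)C`: > 100000 nM (a limit)
- compound 2 `Cc1c(O)ccc2cc(-n3cc(-c4ccc(N(C)C)cc4)nn3)c(=O)oc12`: > 100000 nM (a limit)
- compound 3 `CC(=O)Oc1ccc2cc(-n3cc(/C=C/c4ccccc4)nn3)c(=O)oc2c1C`: 28500 nM

Compound 1 stands at > 100000 nM, which is a limit of the assay and not a number. Compound 2 shows > 100000 nM, which is also only a limit. Compound 3 gives a true number, 28500 nM. The picture so far is therefore (the limit of > 100000 nM in this assay, at which 2 of the 3 values shown sit).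

Compound 4 `CO[C@@H]1[C@@H](O)[C@@H](O)[C@H](Oc2ccc3c(c2C)OC(=O)C(n2cc(-c4c[nH]c5ccccc45)nn2)C3)OC1(C)C` keeps the core of compound 1 and changes a single group: 1H-indol-3-yl in place of 4-methylphenyl on an aromatic carbon. The change, counted out, is 1H-indol-3-yl in place of 4-methylphenyl on an aromatic carbon.

Within the data shown here, no measured pair of compounds shows what this kind of swap does, so any forecast is rough. In this assay no change beyond the scatter is expected, because compound 1 gives > 100000 nM, a limit. A measurable value stays possible since compound 3 gives 28500 nM. The expected move is a number no higher from compound 1 to compound 4 (the limit leaves the size open). Compound 4 is estimated at 100000 nM, with an expected range from 30000 nM to 200000 nM.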

Compound 4, half-maximal inhibitory concentration: 18300 nM
Compound 4: the middle estimate sits 5.5-fold (0.74 log units) above what was measured; measured number outside the range, below it.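

In this assay, among these compounds, this is the first step that can be read between compounds differing in one place: 1H-indol-3-yl in place of 4-methylphenyl gives an at least 5.4-fold lower number from compound 1 to compound 4 (0.73 log units; beyond the scatter). Compound 1 gives > 100000 nM, which is a limit and not a number. Compound 4 gives 18300 nM, a true number. So on this aromatic carbon of the five-membered aromatic ring with 3 nitrogen, changing the group can bring the shared core from the limit to a value that can be read: the limit of > 100000 nM in this assay, at which 2 of the 4 values shown sit.

The compounds shown do not tell which difference between the two groups matters, the added five-membered aromatic ring or the hydrogen-bond donor it carries, since both enter together in this one swap. On these data alone, it also stays open whether a six-membered aromatic ring of carbon only carrying an amine, or a carboxylic acid at the same place, would give a lower or a higher number than compound 4 does.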